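This account rests on a few compounds, and the source may have more. Where it says the series, first, only, none or still open, it means among the compounds named here.

Measured so far in an assay on HL-60 cells for inhibition of glutathione S-transferase P (Homo sapiens), read by spectrophotometry, tested at 5 uM; on this read-out lower numbers stand for less inhibition and higher numbers for more inhibition at the one concentration tested (going by the name of the read-out):
- compound 1 `C=C(C)C(=O)c1ccc(OCc2nc(-c3ccccc3)cs2)cc1Cl` — 100%
- compound 2 `C=C(CC)C(=O)c1ccc(OCc2nc(-c3ccc([N+](=O)[O-])cc3)cs2)c(C)c1C` — 4.4%

Compound 2 stands lowest of the two numbers shown; its nearest neighbour is compound 1, whose value lies far higher, and that gap is beyond the usual scatter of repeated measurements. Among the measured compounds shown here, the two compounds differ in several places at once, so no single structural step between them is counted and the gap cannot be assigned to any one of those differences.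

Compound 3 `C=C(CC)C(=O)c1ccc(OCc2nc(-c3ccc4ccccc4c3)cs2)c(C)c1C` is not yet measured. Against compound 2 it shows one change: naphthalen-2-yl in place of 4-nitrophenyl on an aromatic carbon. Only the group at the aromatic carbon changes; the rest of the structure is kept.

For the measured compounds named here, no measured step of this kind exists, so the direction rests on the two values alone. Compound 1, carrying a phenyl at the same position, gives 100% while compound 2 gives 4.4%; on that basis a step upward from compound 2 is expected for compound 3, of a size beyond the scatter but well short of the value of compound 1. The expected step is a number 25.6 percentage points higher from compound 2 to compound 3 (beyond the scatter). Compound 3 is estimated at 30%, within a range from 5% to 75%.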

Compound 3, a percentage reported as inhibition, at one concentration (the size of the read-out at that concentration, not a potency): 0%
Estimate against measurement, compound 3: 30 percentage points above, and the stated range ends above it.
By their numbers in this assay, from the lowest: compounds 3 and 2 (each within the scatter of the next); then compound 1.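

In this assay, among the compounds shown here, naphthalen-2-yl in place of 4-nitrophenyl on the aromatic carbon next to the ring nitrogen gives the first single-place step, a number 4.4 percentage points lower from compound 2 to compound 3 (within the scatter), and so this exchange of aryl groups leaves the reading unresolved. Both compounds lie at the low end of the read-out at the one concentration tested, so with the rest of the structure kept, this pair does not separate a single nitro-bearing ring from a fused pair of carbon rings, and it gives no ranking of the two groups. Nothing available on these compounds accounts for this result.

On these data alone, it remains open whether the reading of compound 1, 100%, goes with its plain phenyl at this position or with the other places where its structure differs from compound 2, since those differences are not separated by any single step. A plain phenyl on the core of compound 2, or a 4-aminophenyl or 4-carboxyphenyl group at the same carbon, would test whether this position can move the reading at all on that core.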